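A few compounds are considered here, and "the series" means these few. Any claim that something is new, unique, unknown or untested is made for them only; others in the source may bear on it.

Of the compounds shown here, three of one series have been measured in a functional assay for inhibition, read by spectrophotometry, with a stated time of 30 min, tested at 1 uM; a higher number here means more inhibition at the concentration tested (going by the name of the read-out), a lower number less inhibition. Compound 1 `COc1cc(/C=C/C(=O)/C=C(/C=C/c2ccc(OC(C)=O)c(OC)c2)NC2CCCCC2)ccc1OC(C)=O` gives 0.01% in this assay. Compound 2 `CCC(C)NC(=C\C(=O)/C=C/c1ccc(O)cc1)/C=C/c1ccc(O)cc1` gives 0.03% in this assay, and compound 3 `CCC(C)NC(=C\C(=O)/C=C/c1ccc(OC(C)=O)c(OC)c1)/C=C/c1ccc(OC(C)=O)c(OC)c1` gives 0%. The three values lie within the usual scatter of one another, so none of the three can be set apart from the others on this read-out.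

Compound 1 and compound 3 differ in one place only, (cyclohexyl in place of sec-butyl on an amine nitrogen). The step this made, a number 0 percentage points higher from compound 3 to compound 1 (within the scatter), lies within the scatter. The same change, (cyclohexyl in place of sec-butyl on an amine nitrogen), turns compound 2 into compound 4 `O=C(/C=C(/C=C/c1ccc(O)cc1)NC1CCCCC1)/C=C/c1ccc(O)cc1`, which has not yet been measured in this assay. The difference between the core of compound 2 and the core of compound 3 is not broken down here.

Because the earlier step of a number 0 percentage points higher from compound 3 to compound 1 (within the scatter) lay within the scatter, the step of a number 0 percentage points lower from compound 2 to compound 4 (within the scatter) is expected to be just as small. In this assay compound 4 is therefore estimated at 0.02%, with an expected range from 0% to 5%.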

Compound 4, a percentage reported as inhibition, at one concentration (the size of the read-out at that concentration, not a potency): 0.03%
The estimate for compound 4 lay 0 percentage points below the measured number, within the range that was stated.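

In this assay the replacement of sec-butyl by cyclohexyl on the amine nitrogen gave a step of no change at the digits printed from compound 2 to compound 4 (within the scatter), and it reads the same on the two cores shown: the same change on two cores in this assay, a number 0 percentage points higher (within the scatter) from compound 3 to compound 1 and no change at the digits printed (within the scatter) from compound 2 to compound 4, 0 percentage points apart, within the scatter of two such steps. So, for compounds 1 to 4, carrying this change from the core of compound 3 to the core of compound 2 left the read-out within the scatter, and the earlier step described the later one well. This does not show that the change is without effect in general, since neither core gives a read-out that can be set apart from the others, and a step measured this close to the bottom of the assay cannot reveal how the change would act on a core with clear inhibition.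

The compounds shown leave open whether a different group on the amine nitrogen, such as benzyl or a chain ending in a carboxylic acid, would give a read-out set apart from these four. They also leave open how the change would read on any further core.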